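Swapping methoxy for chloro on a growth inhibitor

A few compounds are considered here, and "the series" means these few. Any claim that something is new, unique, unknown or untested is made for them only; others in the source may bear on it.

Of the compounds shown here, two have been measured so far in a functional assay on SNB-75 cells (Homo sapiens) for inhibition; a lower number here means a stronger inhibitor of growth, a higher number a weaker inhibitor of growth. Compound 1, `O=C(/C=C/c1cccc(O)c1)c1cccc(-n2cc(-c3ccc(Cl)cc3)[nH]c2=O)c1`, gives 1460 nM in this assay. Compound 2, `COc1ccc(-c2cn(-c3cccc(C(=O)/C=C/c4ccc(O)c(OC)c4)c3)c(=O)[nH]2)cc1`, gives 4730 nM, the higher of the two numbers, and its gap to compound 1 lies beyond the usual scatter of repeated measurements.

Compound 3, `COc1cc(/C=C/C(=O)c2cccc(-n3cc(-c4ccc(Cl)cc4)[nH]c3=O)c2)ccc1O`, has not yet been measured. Compared with compound 2 it carries chloro in place of methoxy on an aromatic carbon. For the measured compounds named here, no pair of measured compounds differs by this single change, so the size of the step is open. Compound 1 also carries the chloro group and gives 1460 nM, though it differs from compound 3 in another part as well, so only a cautious guide is available. The expected step is a 1.9-fold lower number from compound 2 to compound 3 (0.28 log units; within the scatter). Compound 3 is therefore estimated at 2500 nM, within a range from 1000 nM to 6000 nM.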

Compound 3, concentration for 50% growth inhibition: 2750 nM
Compound 3: the middle estimate sits 1.1-fold (0.04 log units) below what was measured, within the range that was stated.
By their numbers in this assay, from the lowest: compounds 1, 3 and 2 (each within the scatter of the next, the first and the last beyond it).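

For the compounds shown here, replacing 4-methoxyphenyl with 4-chlorophenyl, with the rest of the molecule held fixed, gives a 1.7-fold lower number from compound 2 to compound 3 (0.24 log units; within the scatter) in this assay and is the first direct reading of this change at this position: chloro and methoxy cannot be told apart here. Changing only the other place, 4-hydroxy-3-methoxyphenyl in place of 3-hydroxyphenyl, gives a 1.9-fold higher number from compound 1 to compound 3 (0.27 log units; within the scatter) and likewise stays inside the scatter. Neither single change, taken alone, clearly shifts the number in these compounds.

Nothing measured here gives a reason for the size of these steps.

As far as these compounds go, it remains open whether a group of a different kind at this position, such as an amine or a carboxylic acid, would move the number beyond the scatter.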